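Moving the bromine around the ring on a benzyl sulfide

The source may hold more compounds than are shown below. What is called first, only, known or untested is meant among the compounds shown, and "the series" means these compounds.

Measured compounds:
compound 1 `COc1cc(-c2nnc(SCc3cccc(Br)c3)o2)ccc1O`, 382000 nM
compound 2 `COc1cc(-c2nnc(SCc3ccc(Cl)cc3)o2)ccc1O`, 480000 nM
compound 3 `COc1cc(-c2nnc(SCc3ccccc3Br)o2)ccc1O`, 363000 nM

All three share a core and differ only in the substituted phenyl ring attached to a saturated chain carbon bound to a sulfur. In an ADME assay on cells (Mus musculus, strain BALB/c) for cytotoxicity, read by MTT assay, with a stated time of 24 h (on this read-out higher numbers stand for lower toxicity in this test and lower numbers for higher toxicity in this test), compound 3 sits at the low end of the three numbers, yet every gap to it is within the scatter: the step from compound 1 to compound 3 is a 1.1-fold lower number from compound 1 to compound 3 (0.02 log units; within the scatter) and from compound 2 to compound 3 it is a 1.3-fold lower number from compound 2 to compound 3 (0.12 log units; within the scatter). The step from compound 1 to compound 2 is likewise small, a 1.3-fold higher number from compound 1 to compound 2 (0.10 log units; within the scatter).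

Compound 4 `COc1cc(-c2nnc(SCc3ccc(Br)cc3)o2)ccc1O` is not yet measured. It differs from compound 3 in this way: 4-bromophenyl in place of 2-bromophenyl on a saturated chain carbon bound to a sulfur. The two steps that bear on it are the ones already named, each within the scatter, so no step beyond the scatter is expected in this assay for compound 4. The expected step from compound 3 to compound 4 is a 1.1-fold higher number from compound 3 to compound 4 (0.04 log units; within the scatter). Compound 4 is therefore estimated at 400000 nM, with a range from 250000 nM to 650000 nM.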

Compound 4, half-maximal cytotoxic concentration: 455000 nM
Compound 4: the middle estimate sits 1.1-fold (0.06 log units) below what was measured; the measured number falls inside the stated range.
By their numbers in this assay, from the lowest: compounds 3, 1, 4 and 2 (each within the scatter of the next).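

With 2-bromophenyl, 3-bromophenyl and 4-bromophenyl now all represented on a saturated chain carbon bound to a sulfur, the bromine can be compared across the series in this assay: a 1.3-fold higher number from compound 3 to compound 4 (0.10 log units; within the scatter) and a 1.2-fold higher number from compound 1 to compound 4 (0.08 log units; within the scatter) are both small steps, so moving the bromine around the ring changes nothing beyond the scatter in these compounds. Compound 4 also gives the first direct halogen exchange, bromo in place of chloro on an aromatic carbon, and a 1.1-fold lower number from compound 2 to compound 4 (0.02 log units; within the scatter) is again within the scatter. No measurement is at hand that would explain why these steps stay so small.

All of these rings carry a single halogen, so the compounds shown leave open whether an amine or a carboxylic acid on the ring would give a step beyond the scatter. The same question stands for a longer chain between the sulfur and the ring.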